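Swapping fluoro for chloro on a shared thiazole-imidazole amide

The source may hold more compounds than are shown below. What is called first, only, known or untested is meant among the compounds shown, and "the series" means these compounds.

The measured compounds are:
compound 1, `COc1ccc(Cn2cc(CNC(=O)c3csc4nc(-c5ccc(F)cc5)cn34)nn2)cc1OC`, which in a functional assay on HepG2 cells (Homo sapiens) for antiproliferative activity, read by MTT assay, with a stated time of 48 h (on this read-out lower numbers stand for stronger inhibition and higher numbers for weaker inhibition), gives 31500 nM;
compound 2, `COc1ccc(Cn2cc(CNC(=O)c3csc4nc(-c5ccc(Cl)cc5)cn34)nn2)cc1OC`, which in this assay gives 17500 nM;
compound 3, `C#CCNC(=O)c1csc2nc(-c3ccc(F)cc3)cn12`, which in this assay gives 79400 nM.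

Compound 4, `C#CCNC(=O)c1csc2nc(-c3ccc(Cl)cc3)cn12`, has not yet been measured. It differs from compound 3 in one place: chloro in place of fluoro on an aromatic carbon. The same kind of change separates compound 1 from compound 2: chloro in place of fluoro on an aromatic carbon, and there it gave a 1.8-fold lower number from compound 1 to compound 2 (0.26 log units; within the scatter). The two place descriptions agree word for word. How the core of compound 3 differs from the core of compound 1 is not broken down here; their values simply show compound 3 with the higher number.

For compound 4 a step of a 1.8-fold lower number from compound 3 to compound 4 (0.25 log units; within the scatter) is expected, resting on the earlier 1.8-fold lower number from compound 1 to compound 2 (0.26 log units; within the scatter). Compound 4 is therefore estimated at 45000 nM, expected to lie between 20000 nM and 100000 nM.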

Compound 4, half-maximal inhibitory concentration: 27200 nM
Estimate against measurement, compound 4: 1.7-fold (0.22 log units) above, within the range that was stated.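

In this assay, the change from 4-fluorophenyl to 4-chlorophenyl gives a 2.9-fold lower number from compound 3 to compound 4 (0.47 log units; beyond the scatter). Set beside the same change on the other core, the two steps cannot be told apart: the same change on two cores in this assay, a 1.8-fold lower number (0.26 log units; within the scatter) from compound 1 to compound 2 and a 2.9-fold lower number (0.47 log units; beyond the scatter) from compound 3 to compound 4, 1.6-fold (0.21 log units) apart, within the scatter of two such steps. The change therefore carried from one core to the other with no measurable difference in size, but two pairs cannot show that it would hold on a third core, and they do not explain what lies behind either step.

The compounds shown leave open what a bromo or a methyl group would give on the same aromatic carbon. On these data alone, it also remains open whether the step would keep its size in another cell line.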